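Fluoro to chloro on a growth-inhibiting compound

The source may report more compounds than this note shows. Statements on the series, on what has been measured and on what is new or still open speak of the compounds shown alone.

compound 1 `Cc1ccnc2nc(-c3cccc(Cl)c3)cc(O)c12` gives 25700 nM as measured
compound 2 `Cc1ccc2c(O)cc(-c3cccc(Cl)c3)nc2n1` gives 21400 nM as measured
compound 3 `Cc1cc(C)c2c(O)cc(-c3cccc(F)c3)nc2n1` gives 5620 nM as measured

All three compounds were tested in a functional assay on cells (Tumor Cell line, Homo sapiens) for inhibition (on this read-out lower numbers stand for stronger inhibition of growth and higher numbers for weaker inhibition of growth), where compound 3 has the lowest number of the set. Both compound 1 and compound 2 sit above it by more than the usual scatter of repeated measurements, so compound 3 is the strongest growth inhibitor measured so far.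

The next compound, compound 4 `Cc1cc(C)c2c(O)cc(-c3cccc(Cl)c3)nc2n1`, keeps the core of compound 3 and alters one group. It has chloro in place of fluoro on an aromatic carbon, meta to a large group chloro in place of fluoro on an aromatic carbon here.

For the measured compounds named here, no measured pair shows this swap on its own. Compound 1 and compound 2 do carry chloro, but they also differ from compound 3 elsewhere on the core, so they cannot show what chloro alone does. With that gap in the data, the expectation in this assay is no change beyond the scatter, in either direction. The expected move is small, a 1.1-fold lower number from compound 3 to compound 4 (0.05 log units; within the scatter), and could easily vanish on repeat testing. The estimated value for compound 4 is 5000 nM, with an expected range from 2000 nM to 12500 nM on repeated measurement.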

Compound 4, concentration for total growth inhibition: 26300 nM
Compound 4: the middle estimate sits 5.3-fold (0.72 log units) below what was measured; measured number above the stated range.
By their numbers in this assay, from the lowest: compound 3; then compounds 2, 1 and 4 (each within the scatter of the next).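

In this assay, the swap of chloro for fluoro on an aromatic carbon, meta to a large group, can now be read on its own: it gives a 4.7-fold higher number from compound 3 to compound 4 (0.67 log units; beyond the scatter), so at this position on this core the two halogens are not interchangeable, and fluoro goes with the stronger inhibition of growth. The methyl steps read differently, since adding methyl in place of hydrogen on an aromatic carbon gives a 1.2-fold higher number from compound 2 to compound 4 (0.09 log units; within the scatter) and a 1.0-fold higher number from compound 1 to compound 4 (0.01 log units; within the scatter), which means that with chloro in place neither added methyl shifts the number beyond the scatter. Nothing measured here explains why the halogen swap moves the number while the methyl steps do not.

From the compounds shown here alone, this swap rests on a single pair, so it remains open whether fluoro would also give a lower number on the cores of compound 1 and compound 2, each of which carries one methyl fewer than compound 4. Going by these compounds, it is also open how other groups at this position would compare with fluoro, such as hydrogen, methoxy, trifluoromethyl or an amine.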